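A Single Fluorine on the Phenyl Ring of Compound 1

This account rests on a few compounds, and the source may have more. Where it says the series, first, only, none or still open, it means among the compounds named here.

Compound 1, `CC(C(=O)N1CCN(c2ccccc2)CC1)N1C(=O)CCC1=O`, was tested in a functional assay on the whole organism (strain Swiss) with Mus musculus as the target, in the maximal electroshock model, with a stated time of 0.5 h, at a dose of 300 mg/kg by the intraperitoneal route (on this read-out lower numbers stand for a weaker effect and higher numbers for a stronger effect at the one dose given), and gave 50%. Among the three compounds measured, compound 1 stands second highest. The nearest is compound 2, `CCC(C(=O)N1CCN(c2ccccc2Cl)CC1)N1C(=O)CCC1=O`, which gives 25%, a weaker effect beyond the scatter; compound 2 differs from compound 1 in more than one place, so its value is only set beside that of compound 1 here. The furthest is compound 3, `CC(C(=O)N1CCN(c2ccccc2C(F)(F)F)CC1)N1C(=O)CCC1=O`, which gives 100%. Going by the values given here, the one step from compound 1 that differs in a single place is a number 50 percentage points higher from compound 1 to compound 3 (beyond the scatter), brought about by trifluoromethyl in place of hydrogen on an aromatic carbon.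

Compound 4 is `CC(C(=O)N1CCN(c2cccc(F)c2)CC1)N1C(=O)CCC1=O`. It differs from compound 1 by fluoro in place of hydrogen on an aromatic carbon. The step to compound 3 is the only measured one that bears on this change, and it was large and upward; there, a trifluoromethyl entered, whereas in compound 4 only a fluoro enters, at a place meta to a large group. The step from compound 1 to compound 4 is therefore expected to be upward but smaller, a number 15 percentage points higher from compound 1 to compound 4 (beyond the scatter). Compound 4 is estimated at 65%, with a range from 30% to 100%.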

Compound 4, a percentage reported as activity, at one dose (the size of the read-out at that dose, not a potency): 50%
For compound 4 the middle estimate is 15 percentage points above the measured one, within the range that was stated.
By their numbers in this assay, from the lowest: compound 2; then compounds 1 and 4 (each within the scatter of the next); then compound 3.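

In this assay, fluoro in place of hydrogen on an aromatic carbon, meta to a large group, gives no change at the digits printed from compound 1 to compound 4 (within the scatter). The earlier step, a number 50 percentage points higher from compound 1 to compound 3 (beyond the scatter), came with trifluoromethyl, so a substituent on this aromatic ring does not raise the read-out as such: here the upward step holds for trifluoromethyl and not for this fluoro, and the two compounds differ both in the group that enters and in where it sits. The data offer no measurement that would explain this difference between the two steps.

From the compounds shown here alone, what stays open is whether a larger group at this same place, such as methoxy, a nitrile or trifluoromethyl itself, would leave the read-out flat or lift it. Also open, going by these compounds, is whether fluoro would give the same flat result at another place on the ring.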